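The source may report more compounds than this note shows. Statements on the series, on what has been measured and on what is new or still open speak of the compounds shown alone.

Three compounds share one core and differ in what hangs from it. Compound 1 `O=c1c2cccnc2sn1-c1ccc([N+](=O)[O-])cc1` carries a nitro group on its phenyl ring, and in an assay for inhibition of histone acetyltransferase KAT2B (Homo sapiens), read by fluorescence (on this read-out higher numbers stand for weaker inhibition and lower numbers for stronger inhibition), compound 1 gives 2990 nM. Compound 2 `O=c1c2cccnc2sn1-c1ccc(Br)cc1` carries a bromine in place of that nitro group, but in this assay compound 2 gives "not determined" (no result reported), so no result was reported for it. Within the data shown here, compound 1 therefore stands as the only measured number; there is nothing measured to place it against, neither a stronger nor a weaker neighbour.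

Compound 3 `Cc1cnc2sn(-c3ccc([N+](=O)[O-])cc3)c(=O)c2c1` keeps the nitrophenyl ring of compound 1 and changes only the core: methyl in place of hydrogen on an aromatic carbon. Among the measured compounds shown here, no measured pair shows what such a change does here, so the expectation rests on the small size of the change alone. A single methyl added to the core of compound 1 is expected to shift this assay little, if at all, and the step from compound 1 to compound 3 is estimated at a 1.2-fold lower number from compound 1 to compound 3 (0.08 log units; within the scatter), within the usual scatter of repeated measurements. Compound 3 is expected to give about 2500 nM, with a plausible range from 1000 nM to 7000 nM.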

Compound 3, half-maximal inhibitory concentration: 2720 nM
Estimate against measurement, compound 3: 1.1-fold (0.04 log units) below, and the stated range covers the measured number.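

In this assay putting methyl in place of hydrogen on this aromatic carbon gives a 1.1-fold lower number from compound 1 to compound 3 (0.04 log units; within the scatter) and so leaves the read-out no further apart than repeated measurements of one compound might be. Among these compounds, this is the first measured pair here, and it shows that this carbon of the core, two atoms from the ring nitrogen, can carry one added carbon with no difference beyond the scatter. Nothing shown offers a measured reason for this result.

From the compounds shown here alone, whether the same holds for something larger at this carbon, such as an ethyl group, a longer chain, an amine or a carboxylic acid, stays open, as a single methyl says little about those groups. Going by these compounds, what replacing the nitro group on the phenyl ring does also stays open, since the step from compound 1 to the bromine compound, compound 2, cannot be read.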